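The source may report more compounds than this note shows. Statements on the series, on what has been measured and on what is new or still open speak of the compounds shown alone.

Compound 1 `COc1cc(/C=N/NC(=O)c2cnccn2)ccc1O` is recorded in an ADME assay on Vero cells (Chlorocebus sabaeus) for cytotoxicity, with a stated time of 72 h (on this read-out lower numbers stand for higher toxicity in this test and higher numbers for lower toxicity in this test), at > 30 ug/mL, which is a limit of the assay rather than a number. Compound 2 `COc1ccc(/C(C)=N/NC(=O)c2cnccn2)cc1` in this assay gives > 30 ug/mL, again a limit. So compound 2 stands where both known values stand, namely at the limit of > 30 ug/mL in this assay, at which 2 of the 2 values shown sit, and no step between measured compounds is available. Compound 3 `C/C(=N\NC(=O)c1cnccn1)c1ccc(Br)cc1` differs from compound 2 by bromo in place of methoxy on an aromatic carbon. For the measured compounds named here, with no measured step to lean on, the expected change from compound 2 to compound 3 is a number no higher from compound 2 to compound 3 (the limit leaves the size open), that is, none beyond the scatter. Compound 3 is therefore estimated at 30 ug/mL in this assay, within a range of 12 ug/mL to 75 ug/mL.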

Compound 3, half-maximal cytotoxic concentration: > 30 ug/mL
Compound 3 ended at the assay's limit (the forecaster's own chance of this, stated with the estimate: 65%); the middle value sits exactly at the limit.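

For the compounds shown here, compound 3 gives > 30 ug/mL in this assay, which is a limit, and no step between compound 2 and compound 3 can be read. The compounds shown leave open the actual half-maximal cytotoxic concentration of each, with all of them sitting at one limit: the limit of > 30 ug/mL in this assay, at which 3 of the 3 values shown sit.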